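From a Methylpiperidine Amide to an Anilinoethyl Amide

A few compounds are considered here, and "the series" means these few. Any claim that something is new, unique, unknown or untested is made for them only; others in the source may bear on it.

Within the data shown here, in a functional assay on PANC-1 cells (Homo sapiens) for antiproliferative activity, read by MTT assay, with a stated time of 48 h (on this read-out lower numbers stand for stronger inhibition and higher numbers for weaker inhibition), compound 2 `Cc1c(C(=O)N2CCCC(C)C2)oc2ccc(N(Cc3ccc(Br)cc3)S(=O)(=O)c3ccc(Br)cc3)cc12` gives 26200 nM, the higher of the two numbers measured so far and therefore the weaker inhibition. Among the measured compounds shown here, the only other measured compound, compound 1 `Cc1c(C(=O)NCCCN(C)C)oc2ccc(N(Cc3ccc(Br)cc3)S(=O)(=O)c3ccc(Br)cc3)cc12`, gives 2300 nM on the same core. Compound 3 `Cc1c(C(=O)NCCNc2ccccc2)oc2ccc(N(Cc3ccc(Br)cc3)S(=O)(=O)c3ccc(Br)cc3)cc12`, not yet measured, keeps that core and alters one group: (2-anilinoethyl)amino in place of 3-methylpiperidin-1-yl on a carbonyl carbon. The change places (2-anilinoethyl)amino in place of 3-methylpiperidin-1-yl on a carbonyl carbon.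

For the measured compounds named here, one measured step bears on this change: an 11-fold higher number from compound 1 to compound 2 (1.06 log units; beyond the scatter), a large step beyond the scatter, made at that same carbonyl carbon. Like compound 1, compound 3 carries a chain joined through the amide nitrogen and keeps the amide hydrogen, but its chain ends differently. Only part of that large step is therefore expected to be recovered, and a single pair of compounds offers weak guidance. The expected change is a 3.7-fold lower number from compound 2 to compound 3 (0.57 log units; beyond the scatter), toward stronger inhibition. For compound 3 the estimated value is 7000 nM, with an expected range of 2000 nM to 25000 nM.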

Compound 3, half-maximal inhibitory concentration: > 40000 nM
Compound 3 ended at the assay's limit (the forecaster's own chance of this, stated with the estimate: 5%); middle value at least 5.7-fold (0.75 log units) from the limit.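

Compound 3 reached the limit of this assay, so it has no exact number and both new steps are floors: the limit of > 40000 nM in this assay, at which 1 of the 3 values shown sits.

Compound 1 and compound 3 both carry a chain on the amide nitrogen and keep the amide hydrogen, so these two features alone do not preserve the activity of compound 1. With anilino in place of (dimethylamino)methyl on the chain, the comparison gives an at least 17-fold higher number from compound 1 to compound 3 (1.24 log units; beyond the scatter), showing that the chain end matters a great deal at this carbonyl carbon, which the earlier pair could not separate from the presence of the chain itself. The other comparison gives an at least 1.5-fold higher number from compound 2 to compound 3 (0.18 log units; that floor lies within the scatter), so compound 2 and compound 3 cannot be placed in a firm order, and (2-anilinoethyl)amino shows no gain over 3-methylpiperidin-1-yl.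

The compounds shown leave open whether the large step comes from losing the dimethylamino end or from adding the anilino end. They also do not tell whether a chain ending in a diethylamino or morpholine group would hold the level of compound 1, or whether a dimethylamino group on a shorter chain would do so.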